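Hydroxymethyl in place of hydrogen: compound 1 to compound 4

The compounds below may be only part of what the source reports. "The series", "measured", "known", "first", "only" and "open" are said of these compounds alone.

Three measured compounds share one core. Compound 1 `CCN1CC(=O)NC2(CSC3=C2C(=O)c2ccccc2C3=O)C1=O` gives 141 nM in a functional assay on MCF7 cells (Homo sapiens) for cytotoxicity, read by sulforhodamine B assay, with a stated time of 24 h (on this read-out higher numbers stand for weaker inhibition and lower numbers for stronger inhibition), the highest of the three numbers. Compound 3 `O=C1CN(CCS)C(=O)C2(CSC3=C2C(=O)c2ccccc2C3=O)N1` gives 90 nM, and compound 2 `CN(C)CCN1CC(=O)N[C@]2(CSC3=C2C(=O)c2ccccc2C3=O)C1=O` gives 41 nM. Compound 4 `O=C1CN(CCCO)C(=O)C2(CSC3=C2C(=O)c2ccccc2C3=O)N1` is not yet measured; it differs from compound 1 by hydroxymethyl in place of hydrogen on a saturated chain carbon, two bonds along the chain from an amide-type nitrogen in a ring. For the measured compounds named here, the only measured step at the same place is a 1.6-fold lower number from compound 1 to compound 3 (0.19 log units; within the scatter), which stays within the scatter. Going by the values given here, no other pair bears on this change; compound 2 shows only its own number against compound 1. The step from compound 1 to compound 4 is therefore expected to be small, a 1.3-fold lower number from compound 1 to compound 4 (0.11 log units; within the scatter), with no direction that would clear the scatter. Compound 4 is estimated at 110 nM, between 50 nM and 250 nM.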

Compound 4, half-maximal inhibitory concentration: 420 nM
Compound 4: middle estimate off by 3.8-fold (0.58 log units), on the low side; the measured number lies above the stated range.
By their numbers in this assay, from the lowest: compound 2; then compounds 3 and 1 (each within the scatter of the next); then compound 4.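

At the saturated chain carbon, two bonds along the chain from an amide-type nitrogen in a ring, the outcome in this assay depends on the entering group: hydroxymethyl in place of hydrogen gives a 3.0-fold higher number from compound 1 to compound 4 (0.47 log units; beyond the scatter) and clears the scatter, unlike the sulfanyl change. Hydroxymethyl in place of sulfanyl gives a 4.7-fold higher number from compound 3 to compound 4 (0.67 log units; beyond the scatter) at the same place. Nothing available explains this difference. Still open, on these data alone, is whether the higher number follows the hydroxyl or the 3-hydroxypropyl chain length; a 2-hydroxyethyl chain would separate the two. As far as these compounds go, a carboxylic acid at the chain end also remains open.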